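A Second Chloro Group on the Core of Compound 2

The source may hold more compounds than are shown below. What is called first, only, known or untested is meant among the compounds shown, and "the series" means these compounds.

Two compounds have been measured in a functional assay on OVCAR-4 cells (Homo sapiens) for cytotoxicity, read by sulforhodamine B assay, with a stated time of 48 h; on this read-out lower numbers stand for stronger inhibition of growth and higher numbers for weaker inhibition of growth:

compound 1, `ClCc1ccc(Cn2cnc3nc(Cl)nc(Cl)c32)cc1`, gives 2080 nM
compound 2, `ClCc1ccccc1Cn1cnc2ncnc(Cl)c21`, gives 4890 nM

Compound 2 carries the highest number of the two in this assay; its nearest neighbour is compound 1, whose number is lower by a margin beyond the usual scatter. The two compounds differ in more than one place, so their values show only that they lie apart. Compound 3, `ClCc1ccccc1Cn1cnc2nc(Cl)nc(Cl)c21`, has not yet been measured. It differs from compound 2 by chloro in place of hydrogen on an aromatic carbon. Within the data shown here, no single-change step of this kind has been measured here, so the size of the step is uncertain; a modest move towards a lower number in this assay is expected, though one that could also fall within the scatter. Compound 3 is therefore estimated at 2800 nM, with a range from 1000 nM to 8000 nM. This estimate amounts to an expected step of a 1.7-fold lower number from compound 2 to compound 3 (0.24 log units; within the scatter).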

Compound 3, concentration for 50% growth inhibition: 2130 nM
Compound 3: middle estimate off by 1.3-fold (0.12 log units), on the high side; the range from low to high includes it.
By their numbers in this assay, from the lowest: compounds 1 and 3 (each within the scatter of the next); then compound 2.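

In this assay, among these compounds, chloro in place of hydrogen on the aromatic carbon between two ring nitrogen atoms gives a 2.3-fold lower number from compound 2 to compound 3 (0.36 log units; beyond the scatter), a modest step but the first single change that can be read here. It shows that this carbon accepts a chloro group and that the change goes with stronger inhibition of growth, which compound 1 and compound 2 could not show, as they differ in more than one place. Nothing available explains the size of this step.

On these data alone, whether an amine, a methoxy group or a methyl group on this same carbon would move the number in the same way remains open. As far as these compounds go, it is also open whether the step would be of similar size with the chloromethyl group placed as in compound 1.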